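From Chloro to Methoxy on an Aromatic Ester

This account rests on a few compounds, and the source may have more. Where it says the series, first, only, none or still open, it means among the compounds named here.

In a functional assay on CCRF-CEM cells (Homo sapiens) (a lower number here means a stronger inhibitor, a higher number a weaker inhibitor), compound 3 (`O=C1CCCC/C1=C\c1ccc(OC(=O)c2ccc(Cl)cc2)cc1`) gives 41000 nM and sits at the high end of the three numbers in hand, together with compound 1. Compound 1 (`O=C(/C=C/c1ccc(Cl)c(Cl)c1)Oc1ccc(/C=C2\CCCCC2=O)cc1`) gives 63800 nM and lies within the scatter of compound 3, so the two cannot be told apart. Compound 2 (`CN(C)CC1CCC/C(=C\c2ccc(OC(=O)/C=C/c3ccc(F)cc3)cc2)C1=O`) gives 6000 nM as a lower number than compound 3, by a margin beyond the scatter.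

Compound 4 (`COc1ccc(C(=O)Oc2ccc(/C=C3\CCCCC3=O)cc2)cc1`) has not yet been measured. It departs from compound 3 by a single change (methoxy in place of chloro on an aromatic carbon) with methoxy in place of chloro on an aromatic carbon, para to a large group. Within the data shown here, no two measured compounds differ in only one place, so no measured step speaks directly to this swap. Compound 1 (63800 nM) carries a different group on the acid side of the ester, yet stays within the scatter of compound 3, which suggests little movement. Compound 2 (6000 nM) differs from compound 3 more widely and goes against that reading. What is expected is a 1.0-fold lower number from compound 3 to compound 4 (0.01 log units; within the scatter) within the scatter, with no firm direction. In this assay compound 4 is estimated at 40000 nM and expected to fall between 18000 nM and 90000 nM in most repeat measurements.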

Compound 4, half-maximal inhibitory concentration: 36100 nM
For compound 4 the middle estimate is 1.1-fold (0.04 log units) above the measured one; the range from low to high includes it.
By their numbers in this assay, from the lowest: compound 2; then compounds 4, 3 and 1 (each within the scatter of the next).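

In this assay, among these compounds, the change from 4-chlorophenyl to 4-methoxyphenyl is the first single change that can be read on its own, and it gives a 1.1-fold lower number from compound 3 to compound 4 (0.06 log units; within the scatter) as its step. The earlier compounds shown here could only hint at this, since compound 1 and compound 2 each differ from compound 3 in more than one place. Here the methoxy, with its extra heavy atom and its hydrogen-bond acceptor, replaces the chloro on an aromatic carbon, para to a large group, and the read-out does not separate the two compounds, so this position takes this swap with no visible change in the number.

Going by these compounds, what an amine or a carboxylic acid would do at that same place, para to a large group, stays open, as does whether the step would hold on the core of compound 2, which has the much lower number. Nothing measured in the compounds shown speaks to what lies behind the close match of compound 3 and compound 4.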